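The source may hold more compounds than are shown below. What is called first, only, known or untested is meant among the compounds shown, and "the series" means these compounds.

Measured compounds:
Compound 1 `Cc1ccc(S(=O)(=O)N[C@@H](CC(=O)NC(C)(C)C)C(=O)NCCNC(=O)c2cc(C)ccc2F)cc1`
Compound 2 `Cc1ccc(S(=O)(=O)N[C@@H](CC(=O)NC(C)(C)C)C(=O)NCCNC(=O)c2ccccc2)cc1`
Compound 3 `Cc1ccc(S(=O)(=O)N[C@@H](CC(=O)NC(C)(C)C)C(=O)NCCNC(=O)c2cc(C)ccn2)cc1`

In an ADME assay on Karpas-1106P cells (Homo sapiens) for cytotoxicity (on this read-out higher numbers stand for an effect only at larger amounts of compound and lower numbers for an effect already at smaller amounts), compound 1 gives only a limit, > 11100 nM. Compound 2 likewise returns only a limit, > 11100 nM. Compound 3 too stops at a limit, > 11100 nM. All three values sit at the same limit (the limit of > 11100 nM in this assay, at which 3 of the 3 values shown sit), so compound 2 has no number of its own on this read-out and stands at the edge of what it resolves. The steps among the measured compounds are accordingly not readable: a step that the two limits leave unreadable from compound 1 to compound 2, a step that the two limits leave unreadable from compound 1 to compound 3 and a step that the two limits leave unreadable from compound 2 to compound 3.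

Compound 4 `Cc1ccc(S(=O)(=O)N[C@@H](CC(=O)NC(C)(C)C)C(=O)NCCNC(=O)c2ccccn2)cc1` differs from compound 2 by pyridin-2-yl in place of phenyl on a carbonyl carbon. Among the measured compounds shown here, the only measured step that bears on this change is the closely related one ending in compound 3, a step that the two limits leave unreadable from compound 2 to compound 3, which stays unreadable because both of its ends sit at the limit (the limit of > 11100 nM in this assay, at which 3 of the 3 values shown sit). Neither a direction nor a size can therefore be taken from the numbers; what is expected is that compound 4 again sits at the limit in this assay rather than showing any step beyond the scatter. The step from compound 2 to compound 4 is estimated as a step that the limit leaves unreadable from compound 2 to compound 4. Compound 4 is estimated at 15000 nM, with a range from 8000 nM to 50000 nM.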

Compound 4, half-maximal effective concentration: > 11100 nM
Compound 4 ended at the assay's limit (the forecaster's own chance of this, stated with the estimate: 85%); the middle value lies beyond the limit too.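

No new step can be read for compound 4 against compound 1, compound 2 or compound 3, because all four compounds sit at one limit: the limit of > 11100 nM in this assay, at which 4 of the 4 values shown sit.

The compounds shown leave open whether any change on this carbonyl carbon alters cytotoxicity in this assay, where none of them has a number of its own.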